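The compounds below may be only part of what the source reports. "The series", "measured", "known", "first", "only" and "open" are said of these compounds alone.

Of the compounds shown here, two have been measured in a functional assay on SK-BR-3 cells (Homo sapiens) for activation, read by Western blot; a lower number here means a stronger inhibitor, a higher number a weaker inhibitor. Compound 1, `C=CC(=O)Nc1cc(N)nc(Sc2c(OCC)nc(N3CCCCC3)nc2OCC)n1`, gives 10000 nM. Compound 2, `C=CC(=O)Nc1ccnc(Sc2c(OC)nc(N3CCN(C)CC3)nc2OC)n1`, gives 7500 nM in this assay. The two numbers lie within the usual scatter of each other, so neither compound 2 nor compound 1 can be called the stronger inhibitor on this evidence; both sit at the weak end of what this assay resolves.

Compound 3, `C=CC(=O)Nc1cc(N)nc(Sc2c(OC)nc(N3CCN(C)CC3)nc2OC)n1`, is the compound not yet measured. It differs from compound 2 in one place: amino in place of hydrogen on an aromatic carbon.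

Going by the values given here, no measured pair shows this change by itself, so its effect in this assay is unknown. Compound 1 carries the same amino group on its core, but its other groups also differ from those of compound 2, and its number offers no separate reading of the amino group. Given that compound 1 gives 10000 nM and compound 2 gives 7500 nM, the step from compound 2 to compound 3 is expected to be a 1.2-fold higher number from compound 2 to compound 3 (0.08 log units; within the scatter), that is, no change beyond the scatter. Compound 3 is therefore expected to give about 9000 nM, within a range of 4000 nM to 20000 nM.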

Compound 3, half-maximal inhibitory concentration: 2000 nM
Estimate against measurement, compound 3: 4.5-fold (0.65 log units) above, outside the stated range (below it).
By their numbers in this assay, from the lowest: compound 3; then compounds 2 and 1 (each within the scatter of the next).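

Going by these compounds alone, the single change of amino in place of hydrogen, on the aromatic carbon next to the ring nitrogen and meta to a (vinylcarbonyl)amino group, gives in this assay a 3.8-fold lower number from compound 2 to compound 3 (0.57 log units; beyond the scatter). Within the data shown here, this is the first reading of the amino group by itself, and it shows that this position responds to a substitution in this assay, by a modest step that lies beyond the scatter, which compound 1, with its several other differences, could not show. Nothing measured here accounts for the step, and the data give no explanation of why the amino group has this effect.

The compounds shown leave open whether the step belongs to the amino group in particular, since no other group, such as a methyl, a hydroxyl or a methylamino group, appears at this position. Among these compounds, they also leave open whether the amino group would give a similar step alongside the other groups of compound 1, since no compound here pairs with compound 1 by this change alone.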